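This account rests on a few compounds, and the source may have more. Where it says the series, first, only, none or still open, it means among the compounds named here.

Measured in a functional assay on MCF-10A cells (Homo sapiens) for antiproliferative activity, with a stated time of 48 h; a higher number here means that more compound is needed for the effect, a lower number that less compound is needed:

Compound 1 `COc1ccc2nc(C)cc(NCc3ccccc3)c2c1`: 25900 nM
Compound 2 `COc1ccc2nc(C)cc(NCc3ccccc3OC)c2c1`: 25200 nM
Compound 3 `Cc1cc(NCc2ccc(F)cc2)c2ccccc2n1`: 15400 nM

Compound 1 and compound 2 share a core and differ by methoxy in place of hydrogen on an aromatic carbon. In this assay this gives a 1.0-fold lower number from compound 1 to compound 2 (0.01 log units; within the scatter), so the change leaves the number essentially where it was. Compound 3 carries a different core from compound 1; how the two cores differ is not broken down here. The values of compound 3 and compound 2 sit within the scatter of each other, as do those of compound 3 and compound 1, so no order among the three is claimed.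

Compound 4 `COc1ccc2c(NCc3ccc(F)cc3)cc(C)nc2c1` has not yet been measured in this assay. It differs from compound 3 by methoxy in place of hydrogen on an aromatic carbon. Within the data shown here, this is the same kind of change as the one from compound 1 to compound 2, but the place is not the same: there the methoxy entered ortho to a large group on a ring that is not fused, here it enters on a ring that is part of a fused system of two rings, meta and para to a fused ring. Because the methoxy change gave a 1.0-fold lower number from compound 1 to compound 2 (0.01 log units; within the scatter), the step is expected to be small; compound 4 is estimated at a 1.0-fold lower number from compound 3 to compound 4 (0.01 log units; within the scatter). The estimate for compound 4 in this assay is 15000 nM, within 7000 nM to 35000 nM, with the different place the main source of uncertainty.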

Compound 4, half-maximal effective concentration: 10200 nM
Compound 4: the middle estimate sits 1.5-fold (0.17 log units) above what was measured; measured number inside the range.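

In this assay methoxy in place of hydrogen on an aromatic carbon gives a 1.5-fold lower number from compound 3 to compound 4 (0.18 log units; within the scatter) on the core of compound 3, a step that stays within the scatter, as the earlier one did. Set side by side, the two steps do not differ: the same change on two cores in this assay, a 1.0-fold lower number (0.01 log units; within the scatter) from compound 1 to compound 2 and a 1.5-fold lower number (0.18 log units; within the scatter) from compound 3 to compound 4, 1.5-fold (0.17 log units) apart, within the scatter of two such steps. Among these compounds, this shows that on both cores the change leaves the number within the scatter, but it does not show a general rule: there are only two pairs, the methoxy stands at a different place in each, and neither step is large enough to test whether a real effect carries from one core to the other.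

Still open, as far as these compounds go, is whether an amine, a carboxylic acid or a longer chain in place of the methoxy would give a step beyond the scatter on either core. Also open, from the compounds shown here alone, is whether methoxy at the same place on both cores would give matching steps.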